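Compound 1 to compound 4: cyclopropyl to cyclohexyl

The compounds below may be only part of what the source reports. "The series", "measured", "known", "first", "only" and "open" are said of these compounds alone.

Compound 1 `O=C(NCc1ccc(-c2noc(CCC3CC3)n2)cc1)[C@H]1NCC[C@@H]1O` gives > 50 ug/mL in a physicochemical assay for solubility, at pH 7.4 (on this read-out higher numbers stand for higher solubility and lower numbers for lower solubility), which is a limit of the assay and not a number. Two compounds with heptyl chains give numbers: compound 2 `CCCCCCCc1nc(-c2ccc([C@@H](C)NC(=O)[C@H]3NCC[C@@H]3O)cc2)no1` reads 27 ug/mL and compound 3 `CCCCCCCc1nc(-c2ccc([C@H](CC)NC(=O)[C@H]3NCC[C@@H]3O)cc2)no1` reads 9 ug/mL. Compound 4 `O=C(NCc1ccc(-c2noc(CCC3CCCCC3)n2)cc1)[C@H]1NCC[C@@H]1O` differs from compound 1 by cyclohexyl in place of cyclopropyl on a saturated chain carbon, two bonds along the chain from an aromatic carbon, with cyclohexyl in place of cyclopropyl on a saturated chain carbon, two bonds along the chain from an aromatic carbon. Within the data shown here, no measured pair isolates this change. The expected step in this assay is an at least 3.3-fold lower number from compound 1 to compound 4 (0.52 log units; beyond the scatter), downward and beyond the scatter, an expectation resting on compound 2 at 27 ug/mL and compound 3 at 9 ug/mL. For compound 4 the estimate is 15 ug/mL, with an expected range of 4 ug/mL to 50 ug/mL.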

Compound 4, solubility: 26 ug/mL
Compound 4: the middle estimate sits 1.7-fold (0.24 log units) below what was measured; low and high end bracket the measured number.
By their numbers in this assay, from the lowest: compound 3; then compounds 4 and 2 (each within the scatter of the next). At a limit, above all of these: compound 1.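

Cyclohexyl in place of cyclopropyl at this saturated chain carbon gives an at least 1.9-fold lower number from compound 1 to compound 4 (0.28 log units; that floor lies within the scatter) in this assay. With cyclohexyl at this position, compound 4 gives a measured number, 26 ug/mL, so the 2-cyclohexylethyl side chain can be placed on the scale. The step remains a floor and not a size because compound 1 sits at a limit of the assay: the limit of > 50 ug/mL in this assay, at which 1 of the 4 values shown sits.

On these data alone, the true size of the step remains open. Also open, as far as these compounds go, is how a cyclopentyl group, a longer chain or an amine at this position would compare with cyclohexyl in compound 4.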